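The compounds below may be only part of what the source reports. "The series", "measured", "known", "first", "only" and "open" are said of these compounds alone.

Measured in an ADME assay on microsomes from liver (Rattus norvegicus) for metabolic stability; on this read-out lower numbers stand for a shorter-lived compound and higher numbers for a longer-lived compound:
- compound 1 `CCC(/C=C1\OC(=O)NC1=O)(CC)c1ccc(-c2ccc3cccc(C(C)C)c3c2)[nH]c1=O` (1.88 h)
- compound 2 `O=C1NC(=O)/C(=C/C(c2ccc(-c3ccc4cccc(F)c4c3)[nH]c2=O)C2CCCCC2)O1` (2.39 h)
- compound 3 `CC(C)C(c1ccc(-c2ccc3cccc(F)c3c2)[nH]c1=O)C1C(=O)NC(=O)N1C` (0.263 h)

Compound 2 lies within the scatter of compound 1, while compound 3 sits lower, beyond the scatter. Compound 4 `O=C1NC(=O)/C(=C/C(c2ccccc2)c2ccc(-c3ccc4cccc(F)c4c3)[nH]c2=O)O1` has phenyl in place of cyclohexyl on a saturated chain carbon bound to an aromatic carbon and a double-bonded chain carbon. Among the measured compounds shown here, no measured pair isolates this change. Compound 1 and compound 2 differ at that carbon and elsewhere, yet compound 1 (1.88 h) and compound 2 (2.39 h) stay within the scatter of each other. No step beyond the scatter is therefore expected in this assay, and no direction is favoured. The expected step is small (a 1.2-fold lower number from compound 2 to compound 4 (0.08 log units; within the scatter)). For compound 4 the estimated half-life is 2 h (expected range 0.85 h to 4.5 h).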

Compound 4, half-life: > 3 h
Compound 4: a limit, no number; the forecaster's own chance of this, stated with the estimate: 3%; at least 1.5-fold (0.17 log units) between middle value and limit.
By their numbers in this assay, from the lowest: compound 3; then compounds 1 and 2 (each within the scatter of the next). At a limit, above all of these: compound 4.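

Compound 4 gives > 3 h in this assay as a limit of the assay, not a number. Phenyl in place of cyclohexyl on a saturated chain carbon bound to an aromatic carbon and a double-bonded chain carbon gives an at least 1.2-fold higher number from compound 2 to compound 4 (0.09 log units; that floor lies within the scatter) at this place, so the aromatic ring brings no shorter half-life here. The true size of the step stays unresolved because of the limit: the limit of > 3 h in this assay, at which 1 of the 4 values shown sits.

Going by these compounds, whether a pyridine ring or an amine-bearing chain at this carbon would hold the half-life remains open.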